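Naphthalen-2-yl replaces 2-phenylethenyl on a carbonyl carbon

The source may report more compounds than this note shows. Statements on the series, on what has been measured and on what is new or still open speak of the compounds shown alone.

compound 1 `Cc1ccc(C(=O)Nc2cc(Cl)ccc2OCC(=O)Nc2ccc(S(N)(=O)=O)cc2C)cc1`: 54200 nM
compound 2 `Cc1cc(S(N)(=O)=O)ccc1NC(=O)COc1ccc(Cl)cc1NC(=O)/C=C/c1ccccc1`: 163000 nM

In a functional assay on C8166 cells (Homo sapiens) for cytotoxicity, read by MTT assay (a lower number here means that less compound is tolerated, a higher number that more compound is tolerated), compound 2 stands highest of the two, at 163000 nM. Compound 3 `Cc1cc(S(N)(=O)=O)ccc1NC(=O)COc1ccc(Cl)cc1NC(=O)c1ccc2ccccc2c1` carries naphthalen-2-yl in place of 2-phenylethenyl on a carbonyl carbon. Among the measured compounds shown here, only one measured step bears on this, a 3.0-fold higher number from compound 1 to compound 2 (0.48 log units; beyond the scatter), which put 2-phenylethenyl in place of 4-methylphenyl on a carbonyl carbon. Compound 3 loses that 2-phenylethenyl, so a move to a lower number, of similar or smaller size than a 3.0-fold higher number from compound 1 to compound 2 (0.48 log units; beyond the scatter), is expected, though a single step is thin evidence. The estimated step is a 2.0-fold lower number from compound 2 to compound 3 (0.31 log units; beyond the scatter). For compound 3 the expected value is 80000 nM, with an estimated range from 30000 nM to 200000 nM.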

Compound 3, half-maximal cytotoxic concentration: 37600 nM
Compound 3: the middle estimate sits 2.1-fold (0.33 log units) above what was measured, within the range that was stated.
By their numbers in this assay, from the lowest: compounds 3 and 1 (each within the scatter of the next); then compound 2.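

In this assay, the groups on this carbonyl carbon now separate: 2-phenylethenyl stands apart from naphthalen-2-yl, with a 4.3-fold lower number from compound 2 to compound 3 (0.64 log units; beyond the scatter), whereas naphthalen-2-yl and 4-methylphenyl cannot be told apart, with a 1.4-fold lower number from compound 1 to compound 3 (0.16 log units; within the scatter). Among these three compounds, only 2-phenylethenyl, the one group with a double bond outside aromatic rings, gives the higher number, and no compound shown goes against this. Nothing measured here explains the difference. On these data alone, whether 2-phenylethyl, which lacks that double bond, or an amine at this place would give the higher number remains open.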